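Dichlorophenyl to Difluorophenyl: Expecting the Next Number

A few compounds are considered here, and "the series" means these few. Any claim that something is new, unique, unknown or untested is made for them only; others in the source may bear on it.

Measured compounds:
compound 1, `COc1cc(-c2cc(/C=C/C(=O)c3ccc(Cl)c(Cl)c3)[nH]n2)cc(OC)c1OC`, 101%
compound 2, `COc1ccc(-c2cc(/C=C/C(=O)c3ccc(N)cc3)[nH]n2)cc1OC`, 88%
compound 3, `COc1cc(C(=O)/C=C/c2cc(-c3cc(OC)c(OC)c(OC)c3)n[nH]2)cc(OC)c1OC`, 89%

Of the compounds shown here, three have been measured in a functional assay on ACHN cells (Homo sapiens) for cytotoxicity, read by sulforhodamine B assay, with a stated time of 48 h, tested at 1 uM; on this read-out lower numbers stand for a stronger effect and higher numbers for a weaker effect at the one concentration tested. Compound 1 gives 101%, the highest of the three numbers, which on this read-out means the weakest effect at the one concentration tested. The nearest of the other two is compound 3 with 89%, lower by a margin beyond the scatter, and compound 2 with 88% lies slightly further, also beyond the scatter. Among the measured compounds shown here, none of the three differs from another in one place only, so no single step between measured compounds can be read off.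

Compound 4, `COc1cc(-c2cc(/C=C/C(=O)c3ccc(F)c(F)c3)[nH]n2)cc(OC)c1OC`, has not yet been measured. It differs from compound 1 in one place: 3,4-difluorophenyl in place of 3,4-dichlorophenyl on a carbonyl carbon. The change keeps the count of heavy atoms, the single six-membered aromatic ring of carbon only, and the absence of donors, acceptors and charge; only the two halogens are exchanged.

For the measured compounds named here, with no measured step of this kind to lean on, the expectation rests on compound 1 alone. Compound 4 is expected to stay close to compound 1, the step of a number 4 percentage points lower from compound 1 to compound 4 (within the scatter) being estimated as none beyond the scatter. Compound 4 is therefore estimated at 97% in this assay, within a range from 82% to 110%.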

Compound 4, a percentage reported as activity, at one concentration (the size of the read-out at that concentration, not a potency): 100%
The estimate for compound 4 lay 3 percentage points below the measured number; the range from low to high includes it.
By their numbers in this assay, from the lowest: compounds 2 and 3 (each within the scatter of the next); then compounds 4 and 1 (each within the scatter of the next).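

In this assay, among the compounds shown here, putting 3,4-difluorophenyl in place of 3,4-dichlorophenyl on a carbonyl carbon gives a number 1 percentage points lower from compound 1 to compound 4 (within the scatter), and this is the first step that can be read at one place, since the earlier compounds all differ from one another in more than one place. It shows that, at the one concentration tested, exchanging these two halogens on this ring leaves the read-out within the scatter, so this change does not separate the pair. No measurement is available that could explain this outcome.

The compounds shown leave open whether a group of a different kind at this place, such as a nitrile or a carboxylic acid in place of the two halogens, or a pyridine ring in place of the phenyl ring, would move the number beyond the scatter. They also leave open whether the 3,4-difluorophenyl and 3,4-dichlorophenyl compounds would stay together at any other concentration, as a read-out at one concentration is not a potency.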